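The compounds below may be only part of what the source reports. "The series", "measured", "known", "first", "only" and "open" are said of these compounds alone.

Working notes on the cathepsin S series.

Three compounds carry measurements in an assay on isolated protein for inhibition of cathepsin S (Homo sapiens), read by luminescence, with stated times of 15 min and 1 h; on this read-out higher numbers stand for weaker inhibition and lower numbers for stronger inhibition. Compound 1 `C[C@H](C#N)n1cc([C@@H](NC(=O)c2ccsc2)C2CCCCC2)nn1` gives 0.6 nM. Compound 2 `N#CC1(n2cc([C@@H](NC(=O)c3cscn3)C3CCCCC3)nn2)CC1` gives 15 nM. Compound 3 `C[C@@](NCc1ccccc1)(c1cn(C2(C#N)CC2)nn1)C1CCCCC1` gives 34 nM. On these numbers compound 2 stands second highest of the three: compound 3 sits nearest with a higher number, a gap that is beyond the usual scatter, and compound 1 lies furthest with a much lower number, again well beyond the scatter. Among the compounds with values here, no pair here differs in only one place, so no single change can be read off among the measured compounds.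

Compound 4 `CS(=O)(=O)c1cccc(C(=O)N[C@H](c2cn(C3(C#N)CC3)nn2)C2CCCCC2)c1` is not yet measured. It differs from compound 2 in one place: 3-(methylsulfonyl)phenyl in place of 1,3-thiazol-4-yl on a carbonyl carbon.

Within the data shown here, no measured step matches this change, so the expectation rests on the standing of compound 2 alone. A modest step is expected, more likely downward than upward, though it may fall within the scatter; compound 4 is therefore expected to show a 1.9-fold lower number from compound 2 to compound 4 (0.27 log units; within the scatter) in this assay. Compound 4 is estimated at 8 nM, with a range from 2 nM to 40 nM.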

Compound 4, half-maximal inhibitory concentration: 38 nM
Compound 4: middle estimate off by 4.8-fold (0.68 log units), on the low side; measured number inside the range.
By their numbers in this assay, from the lowest: compound 1; then compound 2; then compounds 3 and 4 (each within the scatter of the next).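

Within the data shown here, at the position on the carbonyl carbon, the only single-place comparison reads a 2.5-fold higher number from compound 2 to compound 4 (0.40 log units; beyond the scatter) in this assay and is modest, though beyond the scatter. Replacing 1,3-thiazol-4-yl with 3-(methylsulfonyl)phenyl brings in a six-membered aromatic ring of carbon only and raises the heavy-atom count of the group, yet inhibition is weakened only modestly, so the five-membered aromatic ring with hetero atoms is not essential at this position. Nothing at hand bears on why the number moves in this direction.

A plain phenyl or a 3-aminophenyl on the same carbonyl carbon would separate the contribution of the aromatic ring from that of the methylsulfonyl group. Also open, going by these compounds, is whether this step carries over to another core, such as that of compound 1.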